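From 4-chlorophenyl to thiophen-3-yl on the shared core

The compounds below may be only part of what the source reports. "The series", "measured", "known", "first", "only" and "open" are said of these compounds alone.

In a functional assay on U-87MG ATCC cells for inhibition, with U-87 MG (Homo sapiens) as the target, read by MTT assay, with a stated time of 48 h (a higher number here means a weaker inhibitor, a lower number a stronger inhibitor), compound 3 `Clc1ccc(-c2nc3ccccn3c2Sc2ccccc2)cc1` gives 30200 nM, the lower of the two actual numbers available. Compound 1 `CCc1ccc(-c2nc3ccccn3c2Sc2ccccc2)cc1` gives 61700 nM, and chloro in place of ethyl accounts for a 2.0-fold lower number from compound 1 to compound 3 (0.31 log units; beyond the scatter). Compound 2 `c1ccc(Sc2c(-c3cccs3)nc3ccccn23)cc1` gives > 100000 nM, which is a limit of the assay and not a number.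

The unmeasured compound 4 `c1ccc(Sc2c(-c3ccsc3)nc3ccccn23)cc1` carries thiophen-3-yl in place of 4-chlorophenyl on an aromatic carbon. Among the compounds with values here, the nearest precedent is compound 2, which bears thiophen-2-yl at that same place, and the pair shows an at least 3.3-fold lower number from compound 2 to compound 3 (0.51 log units; beyond the scatter). The swap of 4-ethylphenyl for thiophen-2-yl gave an at least 1.6-fold higher number from compound 1 to compound 2 (0.20 log units; that floor lies within the scatter), so it adds little. Compound 4 therefore is expected to lose ground in this assay, by a modest step or somewhat more, towards higher numbers. The expected change is a 2.8-fold higher number from compound 3 to compound 4 (0.45 log units; beyond the scatter). Compound 4 is estimated at 85000 nM, with an expected range from 40000 nM to 180000 nM.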

Compound 4, half-maximal inhibitory concentration: 58600 nM
Compound 4: middle estimate off by 1.5-fold (0.16 log units), on the high side; the range from low to high includes it.
By their numbers in this assay, from the lowest: compounds 3, 4 and 1 (each within the scatter of the next, the first and the last beyond it). At a limit, above all of these: compound 2.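

In this assay, thiophen-3-yl on this aromatic carbon of the shared core stays level with both phenyl-bearing compounds, with a 1.9-fold higher number from compound 3 to compound 4 (0.29 log units; within the scatter) and a 1.1-fold lower number from compound 1 to compound 4 (0.02 log units; within the scatter). This five-membered ring therefore holds its place among the six-membered aryl groups, even though compound 3 and compound 1 themselves stand apart beyond the scatter. The change from thiophen-2-yl to thiophen-3-yl gives an at least 1.7-fold lower number from compound 2 to compound 4 (0.23 log units; that floor lies within the scatter), but compound 2 stands at a limit and not a number, so that step offers only a floor: the limit of > 100000 nM in this assay, at which 1 of the 4 values shown sits.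

The compounds shown leave open whether an amine or a carboxylic acid in place of the 4-chlorophenyl would lower the number further. Every compound shown also carries the phenylsulfanyl group, and what replacing it would do remains open.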